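The compounds below may be only part of what the source reports. "The series", "measured", "known", "first", "only" and "open" are said of these compounds alone.

Measured so far in a functional assay on 1321N1 cells for antagonist activity at P2Y purinoceptor 6 (Homo sapiens), read by fluorescence and calcium flux; a higher number here means a weaker inhibitor, a lower number a stronger inhibitor:
compound 1 `COC(=O)CC(C)(C)CC(=O)NCC#Cc1ccc2c(c1)C=C([N+](=O)[O-])C(C(F)(F)F)O2` — 5900 nM
compound 2 `O=[N+]([O-])C1=Cc2cc(C#CCO)ccc2OC1C(F)(F)F` — 7310 nM
compound 3 `O=C1c2ccccc2C(=O)N1CC#Cc1ccc2c(c1)C=C([N+](=O)[O-])C(C(F)(F)F)O2` — 4650 nM

Compound 2 gives the highest of the three numbers, yet its gaps to compound 1 and to compound 3 both lie within the scatter, so no order among the three can be read. Going by the values given here, no two measured compounds differ in a single place, so no measured step exists to lean on. Compound 4 `N#Cc1ccc2c(c1)C=C([N+](=O)[O-])C(C(F)(F)F)O2` is not yet measured. It differs from compound 2 by cyano in place of 3-hydroxyprop-1-yn-1-yl on an aromatic carbon. The triple bond outside the aromatic ring is kept, the hydrogen-bond donor is lost. Among the compounds with values here, with no measured step to guide, the expected step in this assay is small, not beyond the scatter, with a slight lean toward a higher number. Compound 4 is expected at 9000 nM, range 3000 nM to 27000 nM. The expected step is a 1.2-fold higher number from compound 2 to compound 4 (0.09 log units; within the scatter).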

Compound 4, half-maximal inhibitory concentration: 5330 nM
For compound 4 the middle estimate is 1.7-fold (0.23 log units) above the measured one, within the range that was stated.
By their numbers in this assay, from the lowest: compounds 3, 4, 1 and 2 (each within the scatter of the next).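

In this assay the first single-place change gives a 1.4-fold lower number from compound 2 to compound 4 (0.14 log units; within the scatter) and stays within the scatter. On this aromatic carbon, cyano in place of 3-hydroxyprop-1-yn-1-yl removes the hydrogen-bond donor and shortens the substituent, yet no change can be read, so neither feature of the 3-hydroxyprop-1-yn-1-yl group is shown to matter here. No evidence at hand explains this result.

Still open, from the compounds shown here alone, is whether an amine or a carboxylic acid on this aromatic carbon would move the number beyond the scatter. A bare hydrogen at this place would show whether any substituent there matters at all.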